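The compounds below may be only part of what the source reports. "The series", "measured", "known", "first", "only" and "open" are said of these compounds alone.

Three compounds have been measured so far, all in a functional assay on the whole organism (strain albino) with Rattus norvegicus as the target, in the maximal electroshock model, with a stated time of 1 h, at a dose of 30 mg/kg by the intraperitoneal route; on this read-out lower numbers stand for less inhibition and higher numbers for more inhibition at the one dose given (going by the name of the read-out):

Compound 1, `Cc1nc2ccccc2c(=O)n1NCc1nnc(/N=C/c2ccc(N(C)C)cc2)s1`, gives 50%.
Compound 2, `Cc1nc2ccc(Br)cc2c(=O)n1NCc1nnc(/N=C/c2ccc(N(C)C)cc2)s1`, gives 50%.
Compound 3, `Cc1nc2ccc(Br)cc2c(=O)n1NCc1nnc(N2C(=O)CSC2c2ccccc2)s1`, gives 60%.

The three numbers lie within the usual scatter of one another, so none of the compounds can be singled out on this read-out. Compound 2 and compound 1 differ in one place only: hydrogen in place of bromo on an aromatic carbon. This step gave no change at the digits printed from compound 2 to compound 1 (within the scatter). Going by the values given here, compound 3 carries a different side part on a core that otherwise matches compound 2; the difference between the two cores is not broken down here, and the two values show only that compound 3 and compound 2 sit within the scatter of each other.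

Compound 4, `Cc1nc2ccccc2c(=O)n1NCc1nnc(N2C(=O)CSC2c2ccccc2)s1`, has not yet been measured. It stands to compound 3 as compound 1 stands to compound 2: hydrogen in place of bromo on an aromatic carbon. The place is the same, word for word, so this is the same change repeated on the other core, and it occurs twice among the compounds shown.

In this assay, among the compounds with values here, a step of about the same size is expected from compound 3 to compound 4, namely no change at the digits printed from compound 3 to compound 4 (within the scatter), because the only precedent for this change, no change at the digits printed from compound 2 to compound 1 (within the scatter), stayed within the scatter. Compound 4 is therefore estimated at 60%, with a range from 40% to 80%.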

Compound 4, a percentage reported as inhibition, in the whole organism at one dose (the size of the read-out at that dose, not a potency): 60%
The estimate for compound 4 equals the measured number at the digits printed; the measured number falls inside the stated range.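

In this assay, hydrogen in place of bromo on an aromatic carbon gave no change at the digits printed from compound 3 to compound 4 (within the scatter), and the two cases of this change agree: the same change on two cores in this assay, no change at the digits printed (within the scatter) from compound 2 to compound 1 and no change at the digits printed (within the scatter) from compound 3 to compound 4, 0 percentage points apart, within the scatter of two such steps. Within this small set, the change therefore carried from the core of compound 2 to the core of compound 3 with the same outcome, and on neither core did the presence of bromo produce a difference that could be read apart from the scatter. This does not show that bromo has no effect at all, since a small effect could lie hidden in the scatter, and two pairs tested at a single dose give an inhibition size rather than a potency, so they say nothing about other doses, other read-outs or other cores.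

The compounds shown leave open whether any group other than bromo at this place, such as chloro, methoxy, an amine or a carboxylic acid, would move the read-out beyond the scatter. They also leave open what a longer chain in place of the methyl on the shared core would do on either side part.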